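Chalcone arm exchange on a shared core, expected potency

The source may hold more compounds than are shown below. What is called first, only, known or untested is meant among the compounds shown, and "the series" means these compounds.

Compound 1 `COc1ccc(C(=O)/C=C/c2cc(-c3cc(OC)c(OC)c(OC)c3)n3nc(-c4ccccc4)cc3n2)cc1` and compound 2 `COc1ccc(/C=C/C(=O)c2cc(-c3cc(OC)c(OC)c(OC)c3)n3nc(-c4ccccc4)cc3n2)cc1OC` share the same core and differ in the direction in which the linking chain is attached to it. In a functional assay on MDA-MB-231 cells (Homo sapiens) for antiproliferative activity, read by MTT assay, with a stated time of 24 h (a lower number here means a stronger inhibitor, a higher number a weaker inhibitor), compound 1 gives 13200 nM. In this assay compound 2 gives 14200 nM. Compound 2 shows the higher of the two numbers, but its gap to compound 1 lies within the scatter, so the two cannot be ordered against each other. Compound 3 `COc1cc(-c2cc(C(=O)/C=C/c3ccc(C)cc3)nc3cc(-c4ccccc4)nn23)cc(OC)c1OC` carries 4-methylphenyl in place of 3,4-dimethoxyphenyl on a double-bonded chain carbon bound to a double-bonded chain carbon. For the measured compounds named here, no measured pair isolates this exchange, so the expectation for the step from compound 2 to compound 3 in this assay rests only on the weak level both measured compounds share; no movement beyond the scatter is expected, a 1.2-fold lower number from compound 2 to compound 3 (0.07 log units; within the scatter). Compound 3 is therefore estimated at 12000 nM in this assay, with an expected range from 5000 nM to 30000 nM.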

Compound 3, half-maximal inhibitory concentration: 18600 nM
Beside the measured number, compound 3's estimate is 1.6-fold (0.19 log units) below it; low and high end bracket the measured number.
By their numbers in this assay, from the lowest: compounds 1, 2 and 3 (each within the scatter of the next).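

In this assay, 4-methylphenyl in place of 3,4-dimethoxyphenyl on a double-bonded chain carbon bound to a double-bonded chain carbon gives a 1.3-fold higher number from compound 2 to compound 3 (0.12 log units; within the scatter), so at this position the exchange of a hydrogen-bond-acceptor-bearing aryl group for one with no acceptors leaves the reading within the scatter. The exchange on an aromatic carbon, (2-(4-methylphenyl)ethenyl)carbonyl in place of 2-((4-methoxyphenyl)carbonyl)ethenyl, gives a 1.4-fold higher number from compound 1 to compound 3 (0.15 log units; within the scatter), so neither step separates the three compounds at their shared weak level. No available evidence bears on this result.

As far as these compounds go, whether an amine or a carboxylic acid in place of the 4-methylphenyl would hold that level remains open. So does whether any exchange at this position can move the number beyond the scatter.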